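Compound 3 Without Its Cyanomethyl Carbonyl Group

This account rests on a few compounds, and the source may have more. Where it says the series, first, only, none or still open, it means among the compounds named here.

In a functional assay on MKN-45 cells (Homo sapiens) for inhibition, read by MTT assay (a lower number here means a stronger inhibitor, a higher number a weaker inhibitor), compound 3 (`CCOC(=O)c1c(NC(=O)CC#N)sc(C(=O)Nc2ccccc2)c1-c1ccccc1`) gives 590 nM as the middle of three numbers, beyond the scatter from both others. Compound 1 (`CCOC(=O)c1c(N)sc(C(=O)Nc2ccc(Cl)cc2)c1-c1ccccc1`) gives 260 nM and sits lower, while compound 2 (`N#Cc1c(N)sc(C(=O)Nc2ccccc2)c1-c1ccccc1`) gives 7090 nM and sits higher. Compound 4 (`CCOC(=O)c1c(N)sc(C(=O)Nc2ccccc2)c1-c1ccccc1`) is still unmeasured. Its change from compound 3 is hydrogen in place of (cyanomethyl)carbonyl on a nitrogen on an aromatic ring in one place: hydrogen in place of (cyanomethyl)carbonyl on a nitrogen on an aromatic ring. Going by the values given here, no measured pair shows this change. Compound 1 also has a plain amino group and gives 260 nM while compound 2 has one too and gives 7090 nM so the two point in opposite directions. In this assay no step beyond the scatter is therefore expected. The expected step of a 1.2-fold higher number from compound 3 to compound 4 (0.07 log units; within the scatter) stays small. Compound 4 is estimated at 700 nM with an expected range from 200 nM to 2500 nM in this measurement.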

Compound 4, half-maximal inhibitory concentration: 8090 nM
Estimate against measurement, compound 4: 12-fold (1.06 log units) below, outside the stated range (above it).
By their numbers in this assay, from the lowest: compound 1; then compound 3; then compounds 2 and 4 (each within the scatter of the next).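

In this assay, hydrogen in place of (cyanomethyl)carbonyl on this nitrogen gives a 14-fold higher number from compound 3 to compound 4 (1.14 log units; beyond the scatter) and so shows that, on this core, the group counts for much of the inhibition. Hydrogen in place of chloro gives a 31-fold higher number from compound 1 to compound 4 (1.49 log units; beyond the scatter) as a second large step, on an aromatic carbon elsewhere in the molecule. Ethoxycarbonyl in place of cyano gives a 1.1-fold higher number from compound 2 to compound 4 (0.06 log units; within the scatter) and thus no step beyond the scatter. No measurement here explains these steps. From the compounds shown here alone, whether a plain acetyl group on this nitrogen, without the nitrile, would keep the gain remains open.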